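A few compounds are considered here, and "the series" means these few. Any claim that something is new, unique, unknown or untested is made for them only; others in the source may bear on it.

Of the compounds shown here, three of one shared core have been measured so far. Compound 1 `N#CC1=C(N)N(c2ccc(S(N)(=O)=O)cc2)C2=C(C(=O)CCC2)C1c1ccc(Cl)cc1Cl` gives 95% in a functional assay on Ehrlich cells (Mus musculus) for cytotoxicity, read by trypan blue exclusion, with a stated time of 2 h, tested at 100 ug/mL; a lower number here means a weaker effect, a higher number a stronger effect of the compound at the concentration tested. Compound 2 `CCCCNC(=S)NC1=C(C#N)C(c2ccc(Cl)cc2Cl)C2=C(CCCC2=O)N1c1ccc(S(N)(=O)=O)cc1` gives 40% in this assay, and compound 3 `N#CC1=C(N2C(=O)CCC2=O)N(c2ccc(S(N)(=O)=O)cc2)C2=C(C(=O)CCC2)C1c1ccc(Cl)cc1Cl` gives 90% in this assay. Compound 3 therefore stands second highest of the three numbers: its nearest neighbour is compound 1, whose value is within the scatter of its own, and its furthest is compound 2, at a large distance.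

The step now followed goes from compound 3 to compound 4 `N#CC1=C(NS(=O)(=O)c2ccc(Br)cc2)N(c2ccc(S(N)(=O)=O)cc2)C2=C(C(=O)CCC2)C1c1ccc(Cl)cc1Cl`, which has not yet been measured. Its structural change is ((4-bromophenyl)sulfonyl)amino in place of 2,5-dioxopyrrolidin-1-yl on a double-bonded ring carbon. Two measured steps at the same double-bonded ring carbon bear on it. The step of a number 5 percentage points lower from compound 1 to compound 3 (within the scatter) shows that exchanging amino for 2,5-dioxopyrrolidin-1-yl left the number essentially where it was. The step of a number 55 percentage points lower from compound 1 to compound 2 (beyond the scatter) and the step of a number 50 percentage points higher from compound 2 to compound 3 (beyond the scatter) show that a group of seven heavy atoms hung on the amine nitrogen, keeping one amine hydrogen, went with a large loss of activity. Compound 4 likewise carries a substituted amino group with one hydrogen-bond donor, which resembles compound 2 more than compound 3. A drop beyond the scatter is therefore expected, though of uncertain size, so compound 4 is estimated at 55%, between 25% and 85%, a change of a number 35 percentage points lower from compound 3 to compound 4 (beyond the scatter) that is expected rather than known.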

Compound 4, a percentage reported as activity, at one concentration (the size of the read-out at that concentration, not a potency): 100%
Compound 4: the middle estimate sits 45 percentage points below what was measured, outside the stated range (above it).
By their numbers in this assay, from the lowest: compound 2; then compounds 3, 1 and 4 (each within the scatter of the next).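

The (4-bromophenyl)sulfonyl group on the amine nitrogen gives a number 5 percentage points higher from compound 1 to compound 4 (within the scatter), whereas the group of 7 heavy atoms at the same nitrogen gives a number 55 percentage points lower from compound 1 to compound 2 (beyond the scatter), so a substituent there, with the amine hydrogen kept, does not in itself go with a loss of activity in this assay. At the double-bonded ring carbon, the exchange of 2,5-dioxopyrrolidin-1-yl for ((4-bromophenyl)sulfonyl)amino gives a number 10 percentage points higher from compound 3 to compound 4 (within the scatter), so amino, 2,5-dioxopyrrolidin-1-yl and ((4-bromophenyl)sulfonyl)amino cannot be told apart by this read-out at the one concentration tested. With a number 60 percentage points higher from compound 2 to compound 4 (beyond the scatter), the large loss now belongs to compound 2 alone among the four compounds, and it follows the particular group on the nitrogen rather than the presence of a group there.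

No measurement shown offers an explanation for why these two nitrogen substituents part so widely. Still open, as far as these compounds go, is which part of the group in compound 2 goes with the loss, a question that a urea with the same butyl chain, a plain butyl amine or a methanesulfonyl group on that nitrogen would address.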